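The source may report more compounds than this note shows. Statements on the series, on what has been measured and on what is new or still open speak of the compounds shown alone.

Compound 1 `CCC(=O)NC(c1ccc(C)s1)c1cc(Cl)c2cccnc2c1O` and compound 2 `CCC(=O)NC(c1ccc(C)cc1)c1cc(Cl)c2cccnc2c1O` share one core and differ only in the aromatic group attached to the chain carbon that carries the amide nitrogen. In an assay for inhibition of Polyunsaturated fatty acid lipoxygenase ALOX12 (Homo sapiens), read by spectrophotometry (on this read-out higher numbers stand for weaker inhibition and lower numbers for stronger inhibition), compound 1 gives 3500 nM. Compound 2 reaches only a limit in this assay, > 150000 nM, which is the limit of > 150000 nM in this assay, at which 1 of the 2 values shown sits. Among the measured compounds shown here, the single measured step, an at least 42-fold higher number from compound 1 to compound 2 (1.63 log units; beyond the scatter), shows that swapping the 5-methylthiophen-2-yl group for 4-methylphenyl costs a great deal of inhibition.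

Compound 3 `CCC(=O)NC(c1ccc(F)cc1)c1cc(Cl)c2cccnc2c1O` has not yet been measured. Its change from compound 2 is fluoro in place of methyl on an aromatic carbon, so the 4-methylphenyl of compound 2 becomes a 4-fluorophenyl. For the measured compounds named here, no measured step tests a methyl-to-fluoro swap, so the only guide is that compound 2 already sits at the limit. A one-atom change on a compound that has already lost nearly all inhibition is expected to leave it weak, so the step of a number no higher from compound 2 to compound 3 (the limit leaves the size open) is expected to be small. Compound 3 is therefore estimated at 150000 nM, within a range of 40000 nM to 400000 nM, with a real chance that this assay again reports only a limit.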

Compound 3, half-maximal inhibitory concentration: > 50000 nM
Compound 3 was reported as a limit; the forecaster's own chance of this, stated with the estimate: 70%; the middle value is on the limit's open side.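

Compound 3 is again reported only as a limit and not as a number: the limit of > 50000 nM in this assay, at which 1 of the 3 values shown sits. Going by these compounds, the step between compound 2 and compound 3 cannot be read, as both values are limits, so it stays unknown whether fluoro or methyl on this aromatic carbon gives the stronger inhibition. What is new is an at least 14-fold higher number from compound 1 to compound 3 (1.15 log units; beyond the scatter): a large loss now appears with 4-fluorophenyl as well as with 4-methylphenyl, so among these three compounds it is not tied to the methyl of compound 2, and both compounds with a six-membered aromatic ring in this place fall well short of compound 1.

Compound 1 is the only one here with the 5-methylthiophen-2-yl group, which leaves open whether its inhibition belongs to the five-membered ring itself or to the methyl on it, a question that plain thiophen-2-yl or 5-chlorothiophen-2-yl would address. Also open, on these data alone, is whether another group at the para position of the phenyl ring, such as a methoxy or an amine, would give a readable number instead of a limit.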